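Cyano for Hydroxy: Three Measured Compounds, One Expected

The source may hold more compounds than are shown below. What is called first, only, known or untested is meant among the compounds shown, and "the series" means these compounds.

Compound 1 `O=C(N/N=C/c1ccccc1O)c1cnccn1` gives 0% in an ADME assay on J774 cells (Mus musculus) for cytotoxicity, read by MTT assay, with a stated time of 48 h, tested at 150 ug/mL; on this read-out higher numbers stand for a weaker effect at the one concentration tested and lower numbers for a stronger effect.
Compound 2 `O=C(N/N=C/c1ccc(O)cc1)c1cnccn1` gives 80% in this assay.
Compound 3 `N#Cc1ccccc1/C=N/NC(=O)c1cnccn1` gives 70% in this assay.

Compound 1 and compound 2 share the same atoms joined differently; the difference between the two cores is not broken down here. Compound 1 and compound 3 differ by cyano in place of hydroxy on an aromatic carbon and the step is a number 70 percentage points higher from compound 1 to compound 3 (beyond the scatter). Compound 2 and compound 3 lie within the scatter of each other.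

Compound 4 `N#Cc1ccc(/C=N/NC(=O)c2cnccn2)cc1` has not been measured; it differs from compound 2 by cyano in place of hydroxy on an aromatic carbon. This is the same kind of change as from compound 1 to compound 3, but the place differs: para to a large group rather than ortho to a large group. Because compound 2 already gives 80%, the expected step of a number 5 percentage points higher from compound 2 to compound 4 (within the scatter) is small. In this assay compound 4 is estimated at 85%, between 60% and 100%.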

Compound 4, a percentage reported as activity, at one concentration (the size of the read-out at that concentration, not a potency): 100%
Compound 4: the middle estimate sits 15 percentage points below what was measured; measured number inside the range.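

In this assay, cyano in place of hydroxy again gives a higher number, with a number 20 percentage points higher from compound 2 to compound 4 (beyond the scatter), so the direction of the change is the same on both cores shown. The size of the step does not carry over from one core to the other: the same change on two cores in this assay, a number 70 percentage points higher (beyond the scatter) from compound 1 to compound 3 and a number 20 percentage points higher (beyond the scatter) from compound 2 to compound 4, 50 percentage points apart, beyond the scatter of two such steps. For the compounds shown here, with only two pairs, which also differ in where the change sits, this does not show what sets the size of the step, nor that the direction would hold on any further core.

The compounds shown leave open how an amine or a carboxylic acid in place of hydroxy would read in this assay on either core. They also leave open whether a longer chain there would follow cyano or hydroxy.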